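The compounds below may be only part of what the source reports. "The series", "measured", "known", "first", "only" and "open" are said of these compounds alone.

Compound 1 `COc1ccccc1NC1=CC(=O)c2c(nc3n2[C@H]2OC[C@@H](O)[C@H]2OC3)C1=O` is reported in a functional assay on ECa-109 cells for inhibition, with ECa-109 cell line (Homo sapiens) as the target, read by sulforhodamine B assay (on this read-out higher numbers stand for weaker inhibition and lower numbers for stronger inhibition), as > 4000 nM, which is a limit of the assay rather than a number.
Compound 2 `COc1ccc(NC2=CC(=O)c3nc4n(c3C2=O)[C@H]2OC[C@@H](O)[C@H]2OC4)cc1` is reported in this assay as > 4000 nM, again a limit of the assay.
Compound 3 `CCOc1ccc(NC2=CC(=O)c3nc4n(c3C2=O)[C@H]2OC[C@@H](O)[C@H]2OC4)cc1` gives 3210 nM in this assay.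

Compound 1 thus stands at the limit of this assay, and the limit of > 4000 nM in this assay, at which 2 of the 3 values shown sit, shows that it shares that position with compound 2. Among the measured compounds shown here, the only step measured within this set, an at least 1.2-fold lower number from compound 2 to compound 3 (0.09 log units; that floor lies within the scatter), concerns the ether chain on the aromatic ring and does not touch the part of the core that is changed here. Compound 4 `O=C1C(N2CCC2)=CC(=O)c2c1nc1n2[C@H]2OC[C@@H](O)[C@H]2OC1` arises from compound 1 through (azetidin-1-yl in place of (2-methoxyphenyl)amino on a double-bonded ring carbon). For the measured compounds named here, no measured step bears on this exchange, so nothing in the data points to a direction; the only anchor is that compound 1 sits at the limit of this assay, and compound 3, the one compound with a number, also lies close to that limit. Compound 4 is therefore expected to land near the same region, with a step that the limit leaves unreadable from compound 1 to compound 4, and its estimated value in this assay is 5000 nM, between 1500 nM and 20000 nM.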

Compound 4, half-maximal inhibitory concentration: > 16000 nM
Compound 4: no number, only a limit; the forecaster's own chance of this, stated with the estimate: 60%; at least 3.2-fold (0.50 log units) between middle value and limit.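

Compound 4 gives > 16000 nM in this assay, which is a limit of the assay and not a number. Compound 1 also stands at a limit, > 4000 nM, so the step between these two compounds cannot be read. The compounds shown leave open how azetidin-1-yl and (2-methoxyphenyl)amino compare on the shared core.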